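The source may hold more compounds than are shown below. What is called first, only, known or untested is meant among the compounds shown, and "the series" means these compounds.

Compounds measured so far in an assay for inhibition of Fatty-acid amide hydrolase 1 (Rattus norvegicus); a lower number here means a stronger inhibitor, a higher number a weaker inhibitor:
- compound 1, `N#Cc1cccc(-c2cnc(C(=O)CCc3ccc(COc4ccccc4)cc3)o2)n1`: 0.56 nM
- compound 2, `N#Cc1cccc(-c2cnc(C(=O)CCc3ccc(-c4ccccc4)cc3)o2)n1`: 2.9 nM
- compound 3, `O=C(O)c1cccc(-c2cnc(C(=O)CCc3ccc(-c4ccc(CN5CCCCC5)cc4)cc3)o2)n1`: 44 nM

Among these three, compound 1 gives the lowest number in this assay. Compound 2 sits next to it with a 5.2-fold higher number from compound 1 to compound 2 (0.71 log units; beyond the scatter), a step that concerns the far end of the chain and leaves the rest of the molecule alone. For the measured compounds named here, compound 3, with the carboxylic acid and the piperidinylmethyl-substituted biphenyl, lies much further away; its value and that of compound 1 show a wide gap, but since the two differ in more than one place no single step is drawn between them.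

Compound 4, `O=C(CCc1ccc(COc2ccccc2)cc1)c1ncc(I)o1`, changes compound 1 at the opposite end. The difference is iodo in place of 6-cyanopyridin-2-yl on an aromatic carbon. Going by the values given here, none of the measured steps touches this position: the step from compound 1 to compound 2 and the gap to compound 3 all lie at the other end of the molecule, so nothing measured here tests what the loss of the 6-cyanopyridin-2-yl group does. The account therefore leans on the size of what leaves and the size of what enters, and the estimate is correspondingly wide. Compound 4 is expected to give a clearly higher number, a step of a 180-fold higher number from compound 1 to compound 4 (2.25 log units; beyond the scatter). The estimate for compound 4 in this assay is 100 nM, with a range from 15 nM to 600 nM.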

Compound 4, inhibition constant: 4 nM
Beside the measured number, compound 4's estimate is 25-fold (1.40 log units) above it; measured number below the stated range.
By their numbers in this assay, from the lowest: compound 1; then compounds 2 and 4 (each within the scatter of the next); then compound 3.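

At this position, next to the ring oxygen, iodo in place of 6-cyanopyridin-2-yl gives in this assay a 7.1-fold higher number from compound 1 to compound 4 (0.85 log units; beyond the scatter), so the position responds to the change, but only modestly. The earlier compounds shown here all carry a six-membered aromatic ring on this carbon, so they could not show that compound 4, with a single iodine atom there and no ring, nitrile or hydrogen-bond acceptor in that group, still gives 4 nM; the 6-cyanopyridin-2-yl group is therefore not needed for a low number in this assay, although compound 1 stays lower. Nothing at hand bears on what lies behind the size of this step.

The compounds shown leave open how much of the step belongs to the ring, how much to the nitrile and how much to the iodine itself, a question that a plain pyridin-2-yl, a bromine or a bare hydrogen on this carbon would help to separate. They also leave open whether the step keeps its size when the phenoxymethyl end is replaced, for instance by phenyl, or when the chain to the carbonyl is longer.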